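Shortening the amide chain of a sirtuin-6 binder

The source may hold more compounds than are shown below. What is called first, only, known or untested is meant among the compounds shown, and "the series" means these compounds.

Measured compounds:
compound 1 `CCCCNC(=O)CCCSC[C@H](NC(=O)OCc1ccccc1)C(=O)Nc1ccccc1` with 26%
compound 2 `O=C(O)CCNC(=O)CCCSC[C@H](NC(=O)OCc1ccccc1)C(=O)Nc1ccccc1` with 43%

In an assay for inhibition of NAD-dependent protein deacylase sirtuin-6 (Homo sapiens), read by HPLC, with stated times of 15 min and 1 h, tested at 333 uM (on this read-out higher numbers stand for more inhibition at the one concentration tested (going by the name of the read-out) and lower numbers for less inhibition), compound 1 gives the lower of the two numbers; compound 2 sits above it by a number 17 percentage points higher from compound 1 to compound 2 (beyond the scatter). Compound 3 `CNC(=O)CCCSC[C@H](NC(=O)OCc1ccccc1)C(=O)Nc1ccccc1` differs from compound 1 by hydrogen in place of propyl on a saturated chain carbon bound to an amide-type nitrogen. For the measured compounds named here, no measured step trims the chain in this way; the only step known, from compound 1 to compound 2, swaps in a carboxy group instead, so it bears on compound 3 only loosely. The expected step of a number 2 percentage points lower from compound 1 to compound 3 (within the scatter) is therefore none beyond the scatter. Compound 3 is estimated at 24%, with a range from 10% to 40%.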

Compound 3, a percentage reported as inhibition, at one concentration (the size of the read-out at that concentration, not a potency): "not active" (no number reported)
Compound 3: no number reported, so the estimate cannot be set against anything.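

For the compounds shown here, compound 3 is reported only as "not active", with no number, so no step from compound 1 to compound 3 can be read. Nothing shown here offers a reason for this result. The compounds shown leave open how chains between methyl and butyl would compare.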